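This account rests on a few compounds, and the source may have more. Where it says the series, first, only, none or still open, it means among the compounds named here.

Measured in a functional assay on SMMC-7721 cells (Homo sapiens) for inhibition, read by MTT assay, with a stated time of 48 h; on this read-out higher numbers stand for weaker inhibition and lower numbers for stronger inhibition:
- Compound 1 `COc1cc(NC(=O)Nc2ccncc2)cc(-c2cccnc2)c1OC`: 73600 nM
- Compound 2 `COc1ccc(-c2cc(NC(=O)Nc3ccncc3)cc(C(F)(F)F)c2)cn1`: > 300000 nM, which is a limit of the assay and not a number
- Compound 3 `O=C(Nc1ccncc1)Nc1cc(-c2cccnc2)ccc1OC(F)(F)F`: 42800 nM

Only two of these results are true numbers. Compound 3 gives 42800 nM and compound 1 gives 73600 nM, and these two values lie within the usual scatter of each other. Both are high numbers, so inhibition in this assay is weak.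

Compound 4 `O=C(Nc1ccncc1)Nc1cc(-c2cncnc2)ccc1OC(F)(F)F` keeps the rest of compound 3 but carries pyrimidin-5-yl in place of pyridin-3-yl on an aromatic carbon, para to a trifluoromethoxy group: pyrimidin-5-yl in place of pyridin-3-yl on an aromatic carbon.

Among the measured compounds shown here, no measured pair shows this exchange, so any forecast is uncertain and starts from compound 3 at 42800 nM. A small shift toward weaker inhibition in this assay is expected, probably no larger than the scatter. The expected change is a 1.3-fold higher number from compound 3 to compound 4 (0.11 log units; within the scatter). For compound 4 the estimated value is 55000 nM, with an expected range of 20000 nM to 150000 nM.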

Compound 4, half-maximal inhibitory concentration: 3990 nM
For compound 4 the middle estimate is 14-fold (1.14 log units) above the measured one, and the stated range ends above it.
By their numbers in this assay, from the lowest: compound 4; then compounds 3 and 1 (each within the scatter of the next). At a limit, above all of these: compound 2.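

In this assay, the aromatic carbon para to a trifluoromethoxy group proves sensitive to the ring it carries: pyrimidin-5-yl in place of pyridin-3-yl gives an 11-fold lower number from compound 3 to compound 4 (1.03 log units; beyond the scatter). The earlier compounds shown here could not show this, since no two of them differed in one place, whereas here the rest of the molecule stays the same and the number still moves beyond the scatter. Nothing measured here explains why this exchange has so large an effect.

As far as these compounds go, it remains open whether a phenyl ring or a pyrazin-2-yl ring at this position would give a lower or a higher number than pyrimidin-5-yl. From the compounds shown here alone, it is also open whether the same exchange would have a similar effect on the core of compound 1.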